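Two benzyl esters in place of a thioether side chain

The compounds below may be only part of what the source reports. "The series", "measured", "known", "first", "only" and "open" are said of these compounds alone.

Compounds measured so far:
compound 1, `O=C(O)[C@@H]1CCCN1C(=O)CN(c1nc(Cl)nc2[nH]cnc12)C1CC1`, 7.29%
compound 2, `N=C(N)NCCC[C@H](NC(=O)CN(c1ncnc2c1ncn2C1CCCCO1)C1CC1)C(=O)OCc1ccccc1`, 19.6%
compound 3, `CSCC[C@H](NC(=O)CN(c1nc(Cl)nc2[nH]cnc12)C1CC1)C(=O)OCc1ccccc1`, 17.6%

All three compounds were tested in a functional assay on the whole organism (Tail, strain ICR) with Mus musculus as the target, in the tail flick test, with a stated time of 150 min, at a dose of 25 umol/kg by the oral route; a higher number here means a stronger effect of the compound at the dose given, a lower number a weaker effect. Compound 1 gives 7.29%, compound 2 gives 19.6% and compound 3 gives 17.6%. Among these three numbers compound 3 stands second highest. Its nearest neighbour is compound 2, whose value lies within the scatter of repeated measurements, so the two cannot be told apart. Its furthest neighbour is compound 1, whose value is lower by a margin beyond the scatter, so compound 3 does show a stronger effect than compound 1 in this assay.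

The next compound, compound 4, is `O=C(CN(c1nc(Cl)nc2[nH]cnc12)C1CC1)N[C@@H](CC(=O)OCc1ccccc1)C(=O)OCc1ccccc1`. It differs from compound 3 in one place: benzyloxycarbonyl in place of (methylsulfanyl)methyl on a saturated chain carbon, two bonds along the chain from an amide-type nitrogen and a carbonyl carbon. The benzyl ester already present in compound 3 is kept, and the side chain that ends in the new benzyloxycarbonyl group is shorter by one carbon.

Among the measured compounds shown here, no measured pair shows a step of this kind, so there is nothing to lean on beyond the values of compounds 2 and 3, which sit together within the scatter despite their different side chains. The expected step of a number 1.6 percentage points lower from compound 3 to compound 4 (within the scatter) is therefore small, and no change beyond the scatter is expected. For compound 4 a value of 16% is estimated, with a likely range from 6% to 28%.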

Compound 4, a percentage reported as activity, at one dose (the size of the read-out at that dose, not a potency): 6.68%
For compound 4 the middle estimate is 9.3 percentage points above the measured one; low and high end bracket the measured number.
By their numbers in this assay, from the lowest: compounds 4 and 1 (each within the scatter of the next); then compounds 3 and 2 (each within the scatter of the next).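

In this assay, among the compounds shown here, putting benzyloxycarbonyl in place of (methylsulfanyl)methyl on a saturated chain carbon, two bonds along the chain from an amide-type nitrogen and a carbonyl carbon, gives a number 10.9 percentage points lower from compound 3 to compound 4 (beyond the scatter), a modest step, but the only one measured between two compounds that differ in one place. For the compounds shown here, it shows that the effect at this dose is sensitive to what this side chain carries, even with the benzyl ester of compound 3 kept, something the earlier compounds could not show, as no two of them differ in one place only. Nothing in the data shown gives a reason for this step.

Read one bond further out, the change is 2-(methylsulfanyl)ethyl to (benzyloxycarbonyl)methyl, so the end group and the length of the chain change together, and it stays open which of the two goes with the lower number. A benzyloxycarbonyl group on a longer chain, or a carboxylic acid at the end of the shorter one, would help to tell these two apart.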